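The source may report more compounds than this note shows. Statements on the series, on what has been measured and on what is new or still open speak of the compounds shown alone.

Of the compounds shown here, three built on the shared core have been measured in a functional assay on SH-SY5Y cells (Homo sapiens), read by MTT assay, with a stated time of 24 h; a higher number here means that more compound is needed for the effect, a lower number that less compound is needed. Compound 1 `COc1ccc(Cl)cc1N(CC(=O)Nc1cccc2ccccc12)S(=O)(=O)c1ccccc1` gives 17400 nM. Compound 2 `COc1ccc(Cl)cc1N(CC(=O)Nc1ccc(C(F)(F)F)cc1)S(=O)(=O)c1ccccc1` gives 3750 nM, the lowest of the two numbers; its nearest neighbour is compound 1, and the change a 4.6-fold lower number from compound 1 to compound 2 (0.67 log units; beyond the scatter) lies beyond the scatter. Compound 3 `COc1ccc(Cl)cc1N(CC(=O)Nc1ccccc1)S(=O)(=O)c1ccccc1` gives only a limit, > 20000 nM, and that is the limit of > 20000 nM in this assay, at which 1 of the 3 values shown sits. The step of an at least 1.1-fold higher number from compound 1 to compound 3 (0.06 log units; that floor lies within the scatter) is itself a limit and stays within the scatter, whereas an at least 5.3-fold higher number from compound 2 to compound 3 (0.72 log units; beyond the scatter) shows that replacing the trifluoromethyl with hydrogen raises the number at least modestly.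

Compound 4 `COc1ccc(Cl)cc1N(CC(=O)Nc1ccc(Cl)cc1)S(=O)(=O)c1ccccc1` has not yet been measured. Its difference from compound 2 is chloro in place of trifluoromethyl on an aromatic carbon. The two measured steps that bear on it are a 4.6-fold lower number from compound 1 to compound 2 (0.67 log units; beyond the scatter) and an at least 5.3-fold higher number from compound 2 to compound 3 (0.72 log units; beyond the scatter); both show that the group on this aromatic carbon shifts the number, with trifluoromethyl giving the lowest number and hydrogen a limit. Chloro is neither of these, so in this assay a modest rise in the number from compound 2 is expected, rather than a return to the limit. The expected step is a 1.9-fold higher number from compound 2 to compound 4 (0.27 log units; within the scatter). Compound 4 is therefore estimated at 7000 nM, with a range from 3000 nM to 20000 nM.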

Compound 4, half-maximal effective concentration: > 20000 nM
Compound 4 was reported as a limit; the forecaster's own chance of this, stated with the estimate: 20%; middle value at least 2.8-fold (0.45 log units) away from the limit.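

In this assay, the change from trifluoromethyl to chloro on this aromatic carbon gives an at least 5.3-fold higher number from compound 2 to compound 4 (0.72 log units; beyond the scatter), so having a group other than hydrogen at this place does not by itself keep the number low, and of the three groups compared here only trifluoromethyl gives a value that is not a limit. The value of compound 4 is a limit and not a number, and compound 3 stands at that same limit: the limit of > 20000 nM in this assay, at which 2 of the 4 values shown sit.

From the compounds shown here alone, the comparison with the naphthalen-1-yl compound gives an at least 1.1-fold higher number from compound 1 to compound 4 (0.06 log units; that floor lies within the scatter), a floor that separates the two no more than the scatter does, and the step linking the two limits cannot be read, so it remains unknown whether chloro differs from hydrogen here.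

The compounds shown leave open whether the low number of compound 2 is particular to trifluoromethyl or would also appear with a nitrile, a bromo group or a trifluoromethoxy group on the same carbon. They also leave open how far a number below the limit could be reached with an amine or a carboxylic acid at this place.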